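The source may hold more compounds than are shown below. What is called first, only, known or untested is meant among the compounds shown, and "the series" means these compounds.

Measured compounds:
- compound 1, `Cc1ccnc(/C(N)=N/NC(=S)N2CCSCC2)c1`: 89.9%
- compound 2, `Cc1cccc(/C(N)=N/NC(=S)N2CCCCC2)n1`: 85.7%
- compound 3, `Cc1cccc(/C(N)=N/NC(=S)N2CCCC2)n1`: 66.3%

All three were tested in a functional assay on A-375 cells (Homo sapiens) for cytotoxicity, read by MTT assay, with a stated time of 72 h, tested at 100 uM; on this read-out higher numbers stand for more inhibition of growth at the one concentration tested and lower numbers for less inhibition of growth. Compound 1 gives the highest of the three numbers, 89.9%, but its gap to compound 2 lies within the usual scatter, so the two cannot be ranked against each other; only compound 3, at 66.3%, sits clearly lower. Within the data shown here, the single step known so far concerns a different change on a different core: a number 19.4 percentage points lower from compound 2 to compound 3 (beyond the scatter).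

Compound 4, `Cc1ccnc(/C(N)=N/NC(=S)N2CCOCC2)c1`, keeps the core of compound 1 and differs from it in one place, (morpholin-4-yl in place of thiomorpholin-4-yl on a thiocarbonyl carbon). Among the measured compounds shown here, no measured pair shows this exchange of one ring hetero atom for another, and the only known step, the shrinking of the ring on compound 2, does not speak directly to it. With the amine ring kept at the same size, little movement is expected, perhaps a slight easing of the inhibition. The expected step is a number 7.9 percentage points lower from compound 1 to compound 4 (within the scatter). Compound 4 is therefore estimated at 82%, within a range from 65% to 95%.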

Compound 4, percent growth inhibition at one concentration: 90.6%
The estimate for compound 4 lay 8.6 percentage points below the measured number; the measured number falls inside the stated range.
By their numbers in this assay, from the lowest: compound 3; then compounds 2, 1 and 4 (each within the scatter of the next).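

In this assay, morpholin-4-yl in place of thiomorpholin-4-yl on the thiocarbonyl carbon gives a number 0.7 percentage points higher from compound 1 to compound 4 (within the scatter). Among these compounds, on the core of compound 1, then, exchanging the ring sulfur for oxygen at this position causes no readable change, whereas the earlier compounds showed only a change of ring size on a different core, with a number 19.4 percentage points lower from compound 2 to compound 3 (beyond the scatter). Nothing available explains why the number holds through this exchange.

Still open, on these data alone, is whether 4-methylpiperazin-1-yl, a ring with a second nitrogen, would hold the number on the thiocarbonyl carbon of this core, and whether shrinking the ring to pyrrolidin-1-yl would have the same effect here as on the core of compound 2. A reading at one concentration also leaves open whether compound 1 and compound 4 would separate at lower concentrations.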